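From Compound 1 to Compound 3: One Group Exchanged

The compounds below may be only part of what the source reports. "The series", "measured", "known", "first", "only" and "open" are said of these compounds alone.

Among the compounds with values here, in a functional assay on A549 cells (Homo sapiens) for cytotoxicity, read by MTT assay, with a stated time of 72 h (a lower number here means a stronger inhibitor, a higher number a weaker inhibitor), compound 1 `O=C1c2c[n+]([O-])c3ccccc3c2C(=O)c2c1c1ccccc1n2Cc1cn([C@H]2O[C@H](CO)[C@@H](O)[C@H]2O)nn1` gives 2680 nM and stands highest of the two numbers so far, while compound 2 `O=C1c2c[n+]([O-])c3ccccc3c2C(=O)c2c1c1ccccc1n2CCCCN1CCNCC1` gives 540 nM and is the stronger inhibitor. Compound 3 `CC1(C)OC[C@H](Cn2cc(Cn3c4c(c5ccccc53)C(=O)c3c[n+]([O-])c5ccccc5c3C4=O)nn2)O1` keeps the core of compound 1 and carries (2,2-dimethyl-1,3-dioxolan-4-yl)methyl in place of 3,4-dihydroxy-5-(hydroxymethyl)oxolan-2-yl on an aromatic nitrogen, a difference that counts as (2,2-dimethyl-1,3-dioxolan-4-yl)methyl in place of 3,4-dihydroxy-5-(hydroxymethyl)oxolan-2-yl on an aromatic nitrogen in all. Within the data shown here, no measured step covers this exchange. In this assay a small move toward a lower number is expected, estimated as a 1.8-fold lower number from compound 1 to compound 3 (0.25 log units; within the scatter) and close to the scatter. Compound 3 is estimated at 1500 nM within a range from 400 nM to 5000 nM for now.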

Compound 3, half-maximal inhibitory concentration: 340 nM
Compound 3: middle estimate off by 4.4-fold (0.64 log units), on the high side; measured number below the stated range.
By their numbers in this assay, from the lowest: compounds 3 and 2 (each within the scatter of the next); then compound 1.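

In this assay, exchanging 3,4-dihydroxy-5-(hydroxymethyl)oxolan-2-yl for (2,2-dimethyl-1,3-dioxolan-4-yl)methyl on an aromatic nitrogen gives a 7.9-fold lower number from compound 1 to compound 3 (0.90 log units; beyond the scatter) and shows that the group at this position can shift the number beyond the scatter. The entering group has 0 hydrogen-bond donors against 3 and 1 defined stereocentre against 4, but these counts change together, so this one step cannot separate them. Nothing available explains the change. From the compounds shown here alone, what a carboxylic acid or a simple amine would give at this position remains open.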